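The source may hold more compounds than are shown below. What is called first, only, known or untested is meant among the compounds shown, and "the series" means these compounds.

Of the compounds shown here, two built on the shared core have so far been tested in an ADME assay on MT2 cells (Homo sapiens) for cytotoxicity; on this read-out higher numbers stand for lower toxicity in this test and lower numbers for higher toxicity in this test. Compound 1 `COc1ccnc(Nc2ccc(Cl)c(OCC=C(C)C)c2)n1` gives 9000 nM in this assay. Compound 2 `CSc1ccnc(Nc2ccc(Cl)c(OCC=C(C)C)c2)n1` gives 2800 nM in this assay. The two differ only by methylsulfanyl in place of methoxy on an aromatic carbon, and that step is a 3.2-fold lower number from compound 1 to compound 2 (0.51 log units; beyond the scatter). Within the data shown here, on the numbers available, compound 2 therefore holds the lowest value of the two, its only neighbour being compound 1 with its higher number.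

Compound 3 `COCc1ccnc(Nc2ccc(Cl)c(OCC=C(C)C)c2)n1` has not yet been measured. It differs from compound 2 in one place: methoxymethyl in place of methylsulfanyl on an aromatic carbon. Among the measured compounds shown here, only the step from compound 1 to compound 2 speaks to this change, since it also exchanged the group on the same aromatic carbon, and it was modest in size. The group entering in compound 3 carries an oxygen, as the methoxy of compound 1 does, so a number lying between those of compound 1 and compound 2 seems the most reasonable expectation, with a modest rise at most. Compound 3 is therefore expected to give about 5000 nM in this assay, with a range from 2000 nM to 15000 nM, which would mean a 1.8-fold higher number from compound 2 to compound 3 (0.25 log units; within the scatter).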

Compound 3, half-maximal cytotoxic concentration: > 25000 nM
Compound 3 ended at the assay's limit; the forecaster's own chance of this, stated with the estimate: 5%; at least 5.0-fold (0.69 log units) between middle value and limit.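

Compound 3 stands at a limit of this assay, not at a number: the limit of > 25000 nM in this assay, at which 1 of the 3 values shown sits.

This shows that the group on this aromatic carbon, next to the ring nitrogen, can shift the read-out further than the first exchange suggested, since methoxymethyl in place of methylsulfanyl gives an at least 8.9-fold higher number from compound 2 to compound 3 (0.95 log units; beyond the scatter). Methoxymethyl also parts from methoxy, with an at least 2.7-fold higher number from compound 1 to compound 3 (0.44 log units; beyond the scatter), so among the compounds shown, two groups that each carry an oxygen do not give the same result at this position.

Going by these compounds, the true value of compound 3 remains unknown, so the real size of both new steps is open, and they can only be read as minimum sizes. The three compounds also leave open whether a longer chain such as ethoxymethyl, an amine or a carboxylic acid on this same aromatic carbon would reach the limit as well, or whether a small ether group such as methoxymethyl is a particular case.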